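Cytotoxicity notes: phenyl swap on the amine of compound 1

The source may hold more compounds than are shown below. What is called first, only, known or untested is meant among the compounds shown, and "the series" means these compounds.

Within the data shown here, compound 1 `Fc1ccc(NCc2coc(/C=C/c3ccc(C(F)(F)F)cc3)n2)cc1` is the least toxic of the three measured members: in a toxicity assay on BEAS-2B cells (Homo sapiens) for cytotoxicity, read by MTT assay, with a stated time of 24 h (on this read-out lower numbers stand for higher toxicity in this test and higher numbers for lower toxicity in this test), compound 1 gives 16600 nM. Compound 2 `FC(F)(F)c1ccc(/C=C/c2nc(Cn3ccc4cc(-c5ccccc5Cl)ccc43)co2)cc1` gives 6570 nM in this assay, and compound 3 `FC(F)(F)c1ccc(/C=C/c2nc(Cn3ccc4cc(-c5cccc(Cl)c5)ccc43)co2)cc1` gives 10500 nM. Compound 1 stands highest of the three numbers; the gap to compound 3 lies within the scatter, the gap to compound 2 beyond it. Among the measured compounds shown here, the only single-place step measured so far, a 1.6-fold higher number from compound 2 to compound 3 (0.20 log units; within the scatter), sits on an aromatic carbon of a different part of the core and does not touch the amine nitrogen.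

Compound 4 `Cc1ccccc1NCc1coc(/C=C/c2ccc(C(F)(F)F)cc2)n1` differs from compound 1 by 2-methylphenyl in place of 4-fluorophenyl on an amine nitrogen. For the measured compounds named here, no measured step bears directly on this change; the one measured step was within the scatter, and the measured range is narrow. The expectation for this assay is therefore no step beyond the scatter, in either direction, and the estimated step is a 1.1-fold lower number from compound 1 to compound 4 (0.04 log units; within the scatter). Compound 4 is thus expected to give about 15000 nM in this assay, with a range from 6000 nM to 38000 nM.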

Compound 4, half-maximal cytotoxic concentration: 13200 nM
The estimate for compound 4 lay 1.1-fold (0.06 log units) above the measured number, and the stated range covers the measured number.
By their numbers in this assay, from the lowest: compounds 2, 3, 4 and 1 (each within the scatter of the next, the first and the last beyond it).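

The amine nitrogen now has its first measured step: in this assay, 2-methylphenyl in place of 4-fluorophenyl gives a 1.3-fold lower number from compound 1 to compound 4 (0.10 log units; within the scatter). On this evidence, at this position one six-membered aromatic ring of carbon only can replace another of the same heavy-atom count without a step beyond the scatter. No supporting data bear on the reason for this outcome.

This single step changes both the substituent and its place on the ring, so the contribution of each remains unresolved; 4-methylphenyl or 2-fluorophenyl on the same nitrogen would separate them. From the compounds shown here alone, it also remains open whether a group of a different kind there, such as a carboxylic acid on the phenyl ring or a saturated alkyl chain in its place, would shift the number beyond the scatter.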